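A few compounds are considered here, and "the series" means these few. Any claim that something is new, unique, unknown or untested is made for them only; others in the source may bear on it.

In a functional assay on PANC-1 cells (Homo sapiens) for inhibition, read by MTT assay, with a stated time of 24 h (a higher number here means a weaker inhibitor, a lower number a stronger inhibitor), compound 1 `CCOc1cc(=O)n(CCCO)c2c1CC(CC=C(C)C)C(C)(C)C2` gives 7300 nM, level with compound 2 `CC(C)=CCC1Cc2c(OC(=O)Nc3ccc(F)c(F)c3)cc(=O)n(CCCO)c2CC1(C)C` at 7300 nM. Compound 3 `CC(C)=CCC1Cc2c(OC(=O)Nc3ccc(F)c(Cl)c3)cc(=O)n(CCCO)c2CC1(C)C` has not been measured. It carries (3-chloro-4-fluorophenyl)carbamoyl in place of ethyl on an oxygen on an aromatic ring. Going by the values given here, the one measured step that bears on this, no change at the digits printed from compound 1 to compound 2 (within the scatter), puts (3,4-difluorophenyl)carbamoyl in that place and stays within the scatter. No shift beyond the scatter is therefore expected in this assay, and the expected step is a 1.0-fold lower number from compound 1 to compound 3 (0.02 log units; within the scatter). Compound 3 is estimated at 7000 nM, with an expected range of 3500 nM to 14000 nM.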

Compound 3, half-maximal inhibitory concentration: 6800 nM
Compound 3: the middle estimate sits 1.0-fold (0.01 log units) above what was measured, within the range that was stated.
By their numbers in this assay, from the lowest: compounds 3, 1 and 2 (each within the scatter of the next).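

In this assay, a second aryl group on the carbamoyl gives the same picture as the first, with (3-chloro-4-fluorophenyl)carbamoyl in place of ethyl on this oxygen giving (a 1.1-fold lower number from compound 1 to compound 3 (0.03 log units; within the scatter)). The new pair also isolates one atom on that ring: chloro in place of fluoro gives (a 1.1-fold lower number from compound 2 to compound 3 (0.03 log units; within the scatter)), so this swap too stays within the scatter. No available evidence explains why these changes leave the reading within the scatter.

The compounds shown leave open whether a phenylcarbamoyl without halogens, or one carrying a methoxy group or an amine, would also stay within the scatter. They also leave open how a longer alkyl chain in place of ethyl would read.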